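The source may report more compounds than this note shows. Statements on the series, on what has been measured and on what is new or still open speak of the compounds shown alone.

Working notes on the series. Compound 1 `CC1=CC[C@H]2[C@@H]1CC=C(C)[C@@H](CC[C@H]1[C@]3(C)CC[C@H](O)C(C)(C)O[C@H]3CC[C@@]1(C)O)C2(C)C` carries a free hydroxyl on a saturated carbon of the shared core. In a functional assay on MDA-MB-231 cells (Homo sapiens) for antiproliferative activity, read by MTT assay, with a stated time of 72 h (a higher number here means a weaker inhibitor, a lower number a stronger inhibitor), compound 1 gives only a limit, > 50000 nM, and not a number (the limit of > 50000 nM in this assay, at which 1 of the 3 values shown sits). Within the data shown here, compound 3 `CC1=CC[C@H]2[C@@H]1CC=C(C)[C@@H](CC[C@H]1[C@]3(C)CC[C@H](OC(=O)c4ccccc4)C(C)(C)O[C@H]3CC[C@@]1(C)O)C2(C)C` carries a benzoyl on that same oxygen, and in this assay compound 3 gives 18400 nM; the step of an at least 2.7-fold lower number from compound 1 to compound 3 (0.43 log units; beyond the scatter) is the only measured step in the set. Compound 2 `CC1=CC[C@H]2[C@H](CC[C@]2(C)O)C(C)(C)[C@@H]1CC[C@H]1[C@]2(C)CC[C@H](OC(=O)c3ccccc3)C(C)(C)O[C@H]2CC[C@@]1(C)O` is the benzoate on the other variant of the core, and in this assay compound 2 gives 16100 nM, the lowest of the two numbers shown, with compound 3 sitting within the scatter of it.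

Compound 4 `CC1=CC[C@H]2[C@H](CC[C@]2(C)O)C(C)(C)[C@@H]1CC[C@H]1[C@]2(C)CC[C@H](OC(=O)c3ccccc3Cl)C(C)(C)O[C@H]2CC[C@@]1(C)O` differs from compound 2 by chloro in place of hydrogen on an aromatic carbon. Among the measured compounds shown here, no measured step touches the aromatic ring of the benzoyl: the single step, an at least 2.7-fold lower number from compound 1 to compound 3 (0.43 log units; beyond the scatter), concerns putting the benzoyl on or taking it off, not changing it. There is therefore no measured basis for a shift in either direction, and the expectation for compound 4 in this assay is a step of a 1.0-fold lower number from compound 2 to compound 4 (0.00 log units; within the scatter), that is, within the scatter. Compound 4 is estimated at 16000 nM, with a range of 6000 nM to 45000 nM.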

Compound 4, half-maximal inhibitory concentration: 24300 nM
The estimate for compound 4 lay 1.5-fold (0.18 log units) below the measured number; the range from low to high includes it.
By their numbers in this assay, from the lowest: compounds 2, 3 and 4 (each within the scatter of the next). At a limit, above all of these: compound 1.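

The aromatic ring of the benzoyl now has a measured step of its own: in this assay the change reads a 1.5-fold higher number from compound 2 to compound 4 (0.18 log units; within the scatter) and so cannot be told apart from repeat measurement. The earlier compounds shown here showed only that putting a benzoyl on the oxygen moves the number; compound 4 adds that one chloro on an aromatic carbon of that ring, ortho to a large group, turns phenyl into 2-chlorophenyl without a shift beyond the scatter, so this position accepts this single change on the benzoate of compound 2 without a readable effect. Nothing in the data at hand bears on the reading of this step.

Open, as far as these compounds go, is whether the same chloro would behave alike on the benzoate of compound 3, which carries the other variant of the core. Also open, from the compounds shown here alone, is whether a different group on this ring, such as an amine, a carboxylic acid or a methoxy group, or a longer chain in place of the benzoyl, would give a step beyond the scatter in this assay at all.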